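Methoxy in Place of Hydrogen on the Pendant Phenyl Ring

The compounds below may be only part of what the source reports. "The series", "measured", "known", "first", "only" and "open" are said of these compounds alone.

Measured compounds:
Compound 1 `O=c1cc(-c2cccc(O)c2)oc2cc(OCCCCCCCCN3CCCC3)ccc12` gives 43.9% in an ADME assay on HepG2 cells (Homo sapiens) for cytotoxicity, read by MTT assay, with a stated time of 48 h, tested at 10 uM; a higher number here means a stronger effect of the compound at the concentration tested, a lower number a weaker effect.
Compound 2 `O=c1cc(-c2ccccc2)oc2cc(OCCCCCCCCN3CCCC3)ccc12` gives 8.97% in this assay.

Compound 2 stands lowest of the two numbers shown; its nearest neighbour is compound 1, and the change from compound 1 to compound 2 was a number 34.9 percentage points lower from compound 1 to compound 2 (beyond the scatter). That single step is the only one available, and it shows that a substituent on the pendant phenyl ring can shift the read-out a great deal.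

Compound 3 `COc1ccccc1-c1cc(=O)c2ccc(OCCCCCCCCN3CCCC3)cc2o1` is not yet measured. It differs from compound 2 by methoxy in place of hydrogen on an aromatic carbon, or, taken one bond further out, phenyl to 2-methoxyphenyl. Among the compounds with values here, no step with a methoxy group is known, so the one hydroxy step bears only loosely on it: it shows the direction a substituent on this ring took, but methoxy is a different group at a different place.

The step from compound 2 to compound 3 is therefore expected to be a number 9 percentage points higher from compound 2 to compound 3 (within the scatter), upward but smaller than the hydroxy step. For compound 3 the estimate is 18%, ranging from 0% to 40%.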

Compound 3, a percentage reported as inhibition, at one concentration (the size of the read-out at that concentration, not a potency): 24.3%
The estimate for compound 3 lay 6.3 percentage points below the measured number, within the range that was stated.
By their numbers in this assay, from the lowest: compound 2; then compound 3; then compound 1.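

In this assay, the methoxy group, ortho to a large group on the pendant phenyl ring, gave a step of its own: a number 15.3 percentage points higher from compound 2 to compound 3 (beyond the scatter). The hydroxy step is therefore no longer a lone case, since compound 1 and compound 3 each carry a different substituent in a different place on this ring and both stand above the unsubstituted phenyl of compound 2. The two substituted compounds do not match, however, with 2-methoxyphenyl in place of 3-hydroxyphenyl giving a number 19.6 percentage points lower from compound 1 to compound 3 (beyond the scatter), and because this change alters both the group and its place at once, it cannot say which of the two sets the size of the rise.

The compounds shown leave open what happens when the methoxy and hydroxy groups exchange places, and whether a different group on this ring, such as an amine or a carboxylic acid, would also raise the number. Nothing measured here bears on why these groups give different numbers.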